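This account rests on a few compounds, and the source may have more. Where it says the series, first, only, none or still open, it means among the compounds named here.

Going by the values given here, compound 2, with structure `COc1ccc(/C(=C\c2cn(C(C)=O)c3ccc(OCc4ccccc4)cc23)C(=O)O)cc1`, is the only compound here that returns a number in a functional assay on LNCaP cells (Homo sapiens) for cytotoxicity, read by MTT assay, with a stated time of 72 h; on this read-out higher numbers stand for weaker inhibition and lower numbers for stronger inhibition: in that assay compound 2 gives 85000 nM. The other measured compound, compound 1, with structure `CC(=O)n1cc(/C=C(/C(=O)O)c2ccc(Cl)cc2)c2cc(OCc3ccccc3)ccc21`, returns in this assay only > 100000 nM, which is a limit of the assay rather than a number. Because of the limit of > 100000 nM in this assay, at which 1 of the 2 values shown sits, the step of an at least 1.1-fold lower number from compound 1 to compound 2 (0.07 log units; that floor lies within the scatter) is known only as a floor, and that floor lies within the scatter. Both compounds thus sit near the weak end of what this assay can report.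

The unmeasured compound 3, with structure `COc1ccc(OC)c(/C(=C\c2cn(C(C)=O)c3ccc(OCc4ccccc4)cc23)C(=O)O)c1`, differs from compound 2 in one place: 2,5-dimethoxyphenyl in place of 4-methoxyphenyl on a double-bonded chain carbon bound to a carbonyl carbon and a double-bonded chain carbon. Among the compounds with values here, the one measured step concerns a different exchange on the same aromatic ring, and its size is fixed only as a floor within the scatter, so it gives no guide toward a larger move here. The step expected for compound 3 in this assay is no change at the digits printed from compound 2 to compound 3 (within the scatter), meaning no change beyond the scatter. Compound 3 is therefore estimated at 85000 nM, with a range from 35000 nM to 200000 nM, and a real chance that this assay again reports only a limit.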

Compound 3, half-maximal inhibitory concentration: 44100 nM
Compound 3: middle estimate off by 1.9-fold (0.28 log units), on the high side; low and high end bracket the measured number.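

In this assay, putting 2,5-dimethoxyphenyl in place of 4-methoxyphenyl on this double-bonded chain carbon gives a 1.9-fold lower number from compound 2 to compound 3 (0.28 log units; within the scatter), so this ring change does not separate the two compounds, even though the entering group carries one more methoxy group. Set against the 4-chlorophenyl group, the same 2,5-dimethoxyphenyl group gives an at least 2.2-fold lower number from compound 1 to compound 3 (0.35 log units; beyond the scatter), and this is the first step at this position that is printed as beyond the scatter, which the earlier step from the chloro to the methoxy compound was not. This step is known only as a floor, and its true size stays open because compound 1 returns a limit rather than a number: the limit of > 100000 nM in this assay, at which 1 of the 3 values shown sits.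

The compounds shown do not tell whether the difference from compound 1 comes from losing the chloro group or from gaining the methoxy groups, since compound 1 gives no number and compound 2 cannot be told apart from compound 3. They also leave open how this assay would read with an amine or a hydroxyl group on the phenyl ring, or with an ester in place of the carboxylic acid on the shared core.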